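A few compounds are considered here, and "the series" means these few. Any claim that something is new, unique, unknown or untested is made for them only; others in the source may bear on it.

In an ADME assay on Caco-2 cells (Homo sapiens) for permeability, read by LC-MS, in the apical to basolateral direction, with a stated time of 60 min, at pH 6.5 (a lower number here means that the compound crosses the layer more slowly, a higher number that the compound crosses the layer faster), compound 3 (`CC(C)(C)C[C@@H](O)C(=O)N1[C@H](C(=O)NCc2cc(Cl)ccc2-n2cnnn2)C[C@@H]2C[C@@H]21`) stands highest of the three measured compounds at 25 10^-6 cm/s. Compound 2 (`CC(C)(C)OC[C@@H](O)C(=O)N1[C@H](C(=O)NCc2cc(Cl)ccc2-n2cnnn2)C[C@@H]2C[C@@H]21`) gives 4.5 10^-6 cm/s, and compound 1 (`O=C(NCc1cc(Cl)ccc1-n1cnnn1)[C@@H]1C[C@@H]2C[C@@H]2N1C(=O)[C@H](O)Cn1cccn1`) gives 0.45 10^-6 cm/s. Compound 4 (`O=C(NCc1cc(Cl)ccc1-n1cnnn1)[C@@H]1C[C@@H]2C[C@@H]2N1C(=O)[C@H](O)Cc1ccccn1`) carries pyridin-2-yl in place of tert-butyl on a saturated chain carbon, two bonds along the chain from a carbonyl carbon and an oxygen on a saturated carbon.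

The closest guide is the large step of a 56-fold higher number from compound 1 to compound 3 (1.74 log units; beyond the scatter), where tert-butyl replaces 1H-pyrazol-1-yl at this same place. Two modest steps also bear on it: a 10-fold higher number from compound 1 to compound 2 (1.00 log units; beyond the scatter) and a 5.6-fold higher number from compound 2 to compound 3 (0.74 log units; beyond the scatter). Among the measured compounds shown here, no measured compound carries pyridin-2-yl, so the comparison with 1H-pyrazol-1-yl remains indirect. A large fall is therefore expected, running against the direction of the step to compound 3 from compound 1, though perhaps not quite as far. The expected change is a 17-fold lower number from compound 3 to compound 4 (1.22 log units; beyond the scatter). Compound 4 is estimated at 1.5 10^-6 cm/s, with an expected range from 0.5 10^-6 cm/s to 5 10^-6 cm/s.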

Compound 4, apparent permeability: 1.2 10^-6 cm/s
The estimate for compound 4 lay 1.3-fold (0.10 log units) above the measured number, within the range that was stated.
By their numbers in this assay, from the lowest: compound 1; then compound 4; then compound 2; then compound 3.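

In this assay, a six-membered aromatic ring at this place gives a number far under those of both ring-free groups, with a 21-fold lower number from compound 3 to compound 4 (1.32 log units; beyond the scatter) and a 3.8-fold lower number from compound 2 to compound 4 (0.57 log units; beyond the scatter), so the two ring-bearing compounds, compound 1 and compound 4, both fall below compound 2 and compound 3 in this set. The two ring-bearing groups are still not interchangeable, since pyridin-2-yl in place of 1H-pyrazol-1-yl gives a 2.7-fold higher number from compound 1 to compound 4 (0.43 log units; beyond the scatter), a smaller step than either of the other two but still beyond the scatter. Nothing available explains these differences.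

As far as these compounds go, what remains open is whether the low number of compound 4 goes with the ring itself or with its nitrogen, a question that phenyl at this place would address. From the compounds shown here alone, how an amine or a longer chain would behave here also remains unknown.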